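Notes on the step from 2-chlorobenzyl to 4-fluorobenzyl

The source may report more compounds than this note shows. Statements on the series, on what has been measured and on what is new or still open speak of the compounds shown alone.

compound 1 `O=C1/C(=C/c2ccccc2F)CN(Cc2cn(Cc3ccccc3F)nn2)C/C1=C\c1ccccc1F`: 16000 nM
compound 2 `O=C1/C(=C/c2ccccc2F)CN(Cc2cn(Cc3ccccc3Cl)nn2)C/C1=C\c1ccccc1F`: 16500 nM
compound 3 `O=C1/C(=C/c2ccccc2F)CN(Cc2cn(Cc3ccc(F)cc3)nn2)C/C1=C\c1ccccc1F`: not yet measured

All values come from a functional assay on MDA-MB-231 cells (Homo sapiens) for cytotoxicity, read by MTT assay, with a stated time of 24 h; on this read-out lower numbers stand for stronger inhibition and higher numbers for weaker inhibition. Compound 2 stands at 16500 nM, level with compound 1 within the scatter. The next change is 4-fluorophenyl in place of 2-chlorophenyl on a saturated chain carbon bound to an aromatic nitrogen. For the measured compounds named here, one measured step bears on it: a 1.0-fold higher number from compound 1 to compound 2 (0.01 log units; within the scatter), for chloro in place of fluoro on an aromatic carbon. Going by the values given here, no measured compound yet carries the 4-fluorophenyl group, so this evidence is thin. Among the compounds with values here, with only that small step from compound 1 to compound 2 to go on, no shift beyond the scatter is expected in this assay, and no direction is favoured. The expected step is a 1.1-fold lower number from compound 2 to compound 3 (0.04 log units; within the scatter). For compound 3 the estimate is 15000 nM, with an expected range of 8000 nM to 30000 nM.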

Compound 3, half-maximal inhibitory concentration: 10000 nM
For compound 3 the middle estimate is 1.5-fold (0.18 log units) above the measured one; the measured number falls inside the stated range.
By their numbers in this assay, from the lowest: compounds 3, 1 and 2 (each within the scatter of the next).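

Read in this assay, the swap to 4-fluorophenyl at this place gives a 1.7-fold lower number from compound 2 to compound 3 (0.22 log units; within the scatter) and, against the 2-fluorophenyl group, a 1.6-fold lower number from compound 1 to compound 3 (0.20 log units; within the scatter) as its second step. Both steps stay within the scatter, so this place on a saturated chain carbon bound to an aromatic nitrogen now shows that 4-fluorobenzyl, like 2-chlorobenzyl, leaves the number level with the other compounds. The earlier finding covered a change of halogen alone, and these steps extend it to a change of benzyl group. Nothing available accounts for the level numbers or for the size of either step.

The compounds shown leave open whether a group of another kind at this place, such as an amine, a carboxylic acid or a longer chain, would move the number beyond the scatter. All three compounds carry a halogenated benzyl group on the shared core, so they cannot show how far this tolerance reaches.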